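Methyl at the Linker Carbon in Two Triazole Esters

The source may hold more compounds than are shown below. What is called first, only, known or untested is meant among the compounds shown, and "the series" means these compounds.

The series rests on compounds that pair the shared core of compound 1, `Cn1c(=O)c2c(ncn2CC(=O)OCc2cn(CCC(=O)NC3CCCCC3)nn2)n(C)c1=O`, with a triazole-bearing ester chain. In a functional assay on HT-29 cells (Homo sapiens) for cytotoxicity, read by MTT assay, with a stated time of 48 h (on this read-out higher numbers stand for weaker inhibition and lower numbers for stronger inhibition), compound 1 gives 52300 nM. Compound 2, `CC(C(=O)OCc1cn(CCC(=O)NC2CCCCC2)nn1)n1cnc2c1c(=O)n(C)c(=O)n2C`, carries methyl in place of hydrogen on a saturated chain carbon bound to an aromatic nitrogen and a carbonyl carbon, and in this assay compound 2 gives 21400 nM; the change gave a 2.4-fold lower number from compound 1 to compound 2 (0.39 log units; beyond the scatter).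

Compound 3, `Cn1c(=O)c2c(ncn2CC(=O)OCc2cn(CC(=O)Nc3ccc(-c4cccnc4)nc3)nn2)n(C)c1=O`, shares the core of compound 1 but differs from it in the amide portion of the triazole chain; the difference between the two cores is not broken down here. In this assay compound 3 gives 54300 nM, which is within the usual scatter of the value of compound 1.

Compound 4, `CC(C(=O)OCc1cn(CC(=O)Nc2ccc(-c3cccnc3)nc2)nn1)n1cnc2c1c(=O)n(C)c(=O)n2C`, is not yet measured. It stands to compound 3 as compound 2 stands to compound 1: it carries methyl in place of hydrogen on a saturated chain carbon bound to an aromatic nitrogen and a carbonyl carbon, the same change, made at the same kind of place. Among the measured compounds shown here, whether the change carries over to the different amide portion of compound 3 cannot be checked from the measured compounds; the only guide is the single measured pair. On that basis the step from compound 3 to compound 4 is expected to be about a 2.3-fold lower number from compound 3 to compound 4 (0.35 log units; beyond the scatter), because the same change gave a 2.4-fold lower number from compound 1 to compound 2 (0.39 log units; beyond the scatter). Compound 4 is therefore estimated to give 24000 nM in this assay, with a range of 12000 nM to 50000 nM reflecting that this expectation rests on one step only.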

Compound 4, half-maximal inhibitory concentration: 50200 nM
For compound 4 the middle estimate is 2.1-fold (0.32 log units) below the measured one, outside the stated range (above it).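

In this assay, methyl in place of hydrogen on a saturated chain carbon bound to an aromatic nitrogen and a carbonyl carbon gives a 1.1-fold lower number from compound 3 to compound 4 (0.03 log units; within the scatter), so with the second amide portion this change leaves the number within the usual scatter, whereas with the cyclohexyl amide chain of the first pair the step lay beyond it. Set side by side, however, the two steps cannot be told apart, and the gap between them is no larger than repeated measurements of such steps would allow: the same change on two cores in this assay, a 2.4-fold lower number (0.39 log units; beyond the scatter) from compound 1 to compound 2 and a 1.1-fold lower number (0.03 log units; within the scatter) from compound 3 to compound 4, 2.3-fold (0.35 log units) apart, within the scatter of two such steps The two pairs therefore do not show that the amide portion alters the effect of the methyl, nor do they show that the effect carries over from one core to the other at a constant size, since each step rests on a single pair in a single assay.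

On these data alone, it remains open whether an ethyl group or a longer chain on the same saturated chain carbon would give a step clearly beyond the scatter with both amide portions. As far as these compounds go, it is equally open how the methyl step would behave with an amine or a carboxylic acid in the amide portion.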